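The compounds below may be only part of what the source reports. "The series", "measured", "known", "first", "only" and "open" are said of these compounds alone.

Compound 1 `C/C(=N\NC(=O)c1ccc(C(F)(F)F)cc1)c1cnccn1`, compound 2 `C/C(=N\NC(=O)c1ccc([N+](=O)[O-])cc1)c1cnccn1` and compound 3 `C/C(=N\NC(=O)c1ccccc1)c1cnccn1` share one core and differ only in a single group on an aromatic carbon. In a physicochemical assay for lipophilicity (a lower number here means a more polar compound, a higher number a more lipophilic compound), compound 1 gives 2, compound 2 gives 2.1 and compound 3 gives 1.9. Compound 3 carries the lowest of the three numbers as written, with compound 1 nearest and compound 2 furthest, yet both gaps lie within the scatter: a number 0.10 log units lower from compound 1 to compound 3 (within the scatter) and a number 0.20 log units lower from compound 2 to compound 3 (within the scatter). Compound 4 `C/C(=N\NC(=O)c1ccc(Br)cc1)c1cnccn1` is not yet measured; it differs from compound 3 by bromo in place of hydrogen on an aromatic carbon. For the measured compounds named here, no step with bromo has been measured, but the two steps at this aromatic carbon barely moved this assay, so a small shift is expected. Compound 4 is therefore estimated at 2.2, between 1.9 and 2.6, meaning an expected step of a number 0.30 log units higher from compound 3 to compound 4 (within the scatter).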

Compound 4, partition coefficient: 2.9
Beside the measured number, compound 4's estimate is 0.70 log units below it, and the stated range ends below it.
By their numbers in this assay, from the lowest: compounds 3, 1 and 2 (each within the scatter of the next); then compound 4.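

In this assay bromo on this aromatic carbon gives a number 1.00 log units higher from compound 3 to compound 4 (beyond the scatter) and a number 0.80 log units higher from compound 2 to compound 4 (beyond the scatter) and a number 0.90 log units higher from compound 1 to compound 4 (beyond the scatter) as it replaces hydrogen, nitro and trifluoromethyl in turn. For the compounds shown here, the three earlier compounds lie within the scatter of one another, so compound 4 is the first to show that a change at this carbon can move the number beyond the scatter. Nothing among the data explains the size of this step. From the compounds shown here alone, whether chloro, iodo or an amine on the same carbon would stand with compound 4 or with the other three remains open.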